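Compound 3 loses its 4-ethylpiperazin-1-yl group

This account rests on a few compounds, and the source may have more. Where it says the series, first, only, none or still open, it means among the compounds named here.

In an ADME assay on a cell-free system (plasma, Mus musculus) for metabolic stability, read by LC-MS, tested at 2 uM (on this read-out higher numbers stand for a longer-lived compound and lower numbers for a shorter-lived compound), compound 3 (`CCN1CCN(c2ccc3c(c2)oc(=O)n3C(=O)NCCCCc2ccccc2)CC1`) yields only a limit (< 0.0834 h). Compound 1 (`CC(C)N1CCC(c2ccc3c(c2)oc(=O)n3C(=O)NCCCCc2ccccc2)CC1`) gives 0.667 h and compound 2 (`CC(=O)N1CCC(c2ccc3c(c2)oc(=O)n3C(=O)NCCCCc2ccccc2)CC1`) gives 0.5 h on the same read-out. Compound 4 (`CN1CCC(c2ccc3c(c2)oc(=O)n3C(=O)NCCCCc2ccccc2)CC1`) carries 1-methylpiperidin-4-yl in place of 4-ethylpiperazin-1-yl on an aromatic carbon. Two measured steps make the opposite swap, with other piperidine groups: an at least 7.9-fold lower number from compound 1 to compound 3 (0.90 log units; beyond the scatter) and an at least 5.9-fold lower number from compound 2 to compound 3 (0.77 log units; beyond the scatter). Changing the group on the piperidine nitrogen mattered little (a 1.3-fold lower number from compound 1 to compound 2 (0.13 log units; within the scatter)). A rise of similar size is therefore expected here (an at least 7.1-fold higher number from compound 3 to compound 4 (0.85 log units; beyond the scatter)). For compound 4 the estimated half-life is 0.6 h (expected range 0.25 h to 1.3 h).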

Compound 4, half-life: 0.833 h
Compound 4: middle estimate off by 1.4-fold (0.14 log units), on the low side; low and high end bracket the measured number.
By their numbers in this assay, from the lowest: compounds 2, 1 and 4 (each within the scatter of the next). At a limit, below all of these: compound 3.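

In this assay, the step to 1-methylpiperidin-4-yl is an at least 9.9-fold higher number from compound 3 to compound 4 (0.99 log units; beyond the scatter), so a third piperidine now stands apart from the 4-ethylpiperazin-1-yl group. Methyl on the piperidine nitrogen cannot be told apart from acetyl or isopropyl, with a 1.7-fold higher number from compound 2 to compound 4 (0.22 log units; within the scatter) and a 1.2-fold higher number from compound 1 to compound 4 (0.10 log units; within the scatter). One end of the step from compound 3 is a limit, so its exact size stays open: the limit of < 0.0834 h in this assay, at which 1 of the 4 values shown sits.

The compounds shown leave open whether the gap follows the piperazine ring or the ethyl group on it. A 4-acetylpiperazin-1-yl group, set against compound 2, would test this.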